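This account rests on a few compounds, and the source may have more. Where it says the series, first, only, none or still open, it means among the compounds named here.

Measured so far in a functional assay on HeLa cells (Homo sapiens) for antiproliferative activity, read by MTT assay, with a stated time of 48 h; a higher number here means a weaker inhibitor, a lower number a stronger inhibitor:
- Compound 1 `COc1ccc(CNc2ccc3ncc(-c4cnn(C)c4)cc3n2)cc1`: > 50000 nM
- Compound 2 `Cn1cc(-c2cnc3ccc(NS(=O)(=O)c4ccc(C(F)(F)F)cc4)nc3c2)cn1`: > 50000 nM
- Compound 3 `Cn1cc(-c2cnc3ccnc(NS(=O)(=O)c4ccc(C(F)(F)F)cc4)c3c2)cn1`: > 50000 nM

Each entry is a limit of the assay and not a number. Compound 3 stands at the limit of > 50000 nM in this assay, at which 3 of the 3 values shown sit. No order among the three compounds can be read from these results.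

Compound 4 `Cn1cc(-c2cnc3ccnc(NS(=O)(=O)c4c(Cl)cccc4Cl)c3c2)cn1` keeps the shared core of compound 3 and changes one group, with 2,6-dichlorophenyl in place of 4-(trifluoromethyl)phenyl on a sulfonyl sulfur. Among the compounds with values here, no pair of measured compounds shows the size of a step, so this expectation has little to rest on. Compound 3 is the closest guide, and its > 50000 nM is a limit.

In this assay, no change beyond the usual scatter is expected, so no direction is predicted. The expected a number no higher from compound 3 to compound 4 (the limit leaves the size open) is therefore small. For compound 4 the estimate is 50000 nM, with an expected range from 15000 nM to 80000 nM.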

Compound 4, half-maximal inhibitory concentration: > 50000 nM
Compound 4 ended at the assay's limit (the forecaster's own chance of this, stated with the estimate: 75%); the middle value lies on the limit itself.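

Compound 3 and compound 4 each give only a limit in this assay, not a number, so the step between them cannot be read: the limit of > 50000 nM in this assay, at which 4 of the 4 values shown sit.

As far as these compounds go, whether any structural change would bring a readable value in this assay stays open, as does any order among compound 1, compound 2, compound 3 and compound 4.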